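Swapping the terminal amine ring on compound 3's side chain

A few compounds are considered here, and "the series" means these few. Any claim that something is new, unique, unknown or untested is made for them only; others in the source may bear on it.

In a functional assay on the whole organism for antagonist activity, with Rattus norvegicus as the target (on this read-out higher numbers stand for an effect only at larger amounts of compound and lower numbers for an effect already at smaller amounts), three compounds sharing one core have been tested. Compound 1 `CN1CCN(CCCCOc2cc(C(=O)N3CCCCc4sccc43)ccc2NC(=O)c2ccccc2-c2ccccc2)CC1` reaches only a limit of the assay, < 0.01 mg/kg. Compound 2 `O=C(Nc1ccc(C(=O)N2CCCCc3sccc32)cc1O)c1ccccc1-c1ccccc1` gives 0.04 mg/kg. Compound 3 `CN1CCN(C(=O)CCCOc2cc(C(=O)N3CCCCc4sccc43)ccc2NC(=O)c2ccccc2-c2ccccc2)CC1` gives 0.03 mg/kg, the lower of the two numbers, although the step of a 1.3-fold lower number from compound 2 to compound 3 (0.12 log units; within the scatter) lies within the scatter, so compound 2 and compound 3 cannot be told apart.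

The measured steps all concern the chain on the aromatic oxygen. Removing that chain gives an at least 4.0-fold higher number from compound 1 to compound 2 (0.60 log units; beyond the scatter), and turning its methylene into a carbonyl gives an at least 3.0-fold higher number from compound 1 to compound 3 (0.47 log units; beyond the scatter); both are given only as lower bounds because of the limit of < 0.01 mg/kg in this assay, at which 1 of the 3 values shown sits.

Compound 4 `CCN(CC)C1CCN(C(=O)CCCOc2cc(C(=O)N3CCCCc4sccc43)ccc2NC(=O)c2ccccc2-c2ccccc2)CC1` differs from compound 3 at the far end of the chain: 4-(diethylamino)piperidin-1-yl in place of 4-methylpiperazin-1-yl on a carbonyl carbon. Going by the values given here, no measured step touches this amine ring, and the only pair that shares the carbonyl-linked chain, compound 2 and compound 3, shows no difference beyond the scatter. The expected step is therefore none beyond the scatter, no change at the digits printed from compound 3 to compound 4 (within the scatter). Compound 4 is estimated at 0.03 mg/kg, with a range from 0.01 mg/kg to 0.1 mg/kg.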

Compound 4, dose for 50% inhibition: 0.01 mg/kg
Compound 4: the middle estimate sits 3.0-fold (0.48 log units) above what was measured, and the stated range covers the measured number.
By their numbers in this assay, from the lowest: compound 4; then compounds 3 and 2 (each within the scatter of the next).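

The far end of the chain turns out not to be a silent position: in this assay, 4-(diethylamino)piperidin-1-yl in place of 4-methylpiperazin-1-yl on the carbonyl carbon gives a 3.0-fold lower number from compound 3 to compound 4 (0.48 log units; beyond the scatter). Going by these compounds alone, this is a modest step, but it is the first measured change at this end of the chain, and it goes beyond the scatter, unlike the earlier step that added the whole carbonyl-linked chain, a 1.3-fold lower number from compound 2 to compound 3 (0.12 log units; within the scatter). The entering group has more heavy atoms and one fewer ring hetero atom, while both groups have the same hydrogen-bond donor and acceptor counts and no net charge, so those two counts do not separate compound 3 from compound 4.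

This single pair cannot show whether the added carbons or the change of ring goes with the lower number, and a 4-(dimethylamino)piperidin-1-yl or morpholin-4-yl group on the same carbonyl carbon would help to separate the two. Room to see still lower numbers in this series is also short, since compound 4 at 0.01 mg/kg stands close to the end of the numeric range: the limit of < 0.01 mg/kg in this assay, at which 1 of the 4 values shown sits.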